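Series notes: hydroxymethyl in place of the benzylamine arm

The compounds below may be only part of what the source reports. "The series", "measured", "known", "first", "only" and "open" are said of these compounds alone.

Compound 1, `COc1ccc(CNCc2c(OC)cc(Oc3cccc(Nc4ccccc4)c3)cc2OC)cc1`, 1890 nM
Compound 2, `COc1cc(Oc2cccc(Nc3ccccc3)c2)cc(OC)c1CNCc1ccccc1`, 3340 nM
Compound 3, `COc1cc(Oc2cccc(Nc3ccccc3)c2)cc(OC)c1CNCc1ccc(Cl)cc1`, 3350 nM

All three numbers come from a functional assay on HT-29 cells (Homo sapiens) for inhibition, read by MTT assay, with a stated time of 72 h; on this read-out lower numbers stand for stronger inhibition and higher numbers for weaker inhibition. Among the compounds with values here, compound 1 gives the lowest of the three, yet the gaps a 1.8-fold higher number from compound 1 to compound 2 (0.25 log units; within the scatter) and a 1.8-fold higher number from compound 1 to compound 3 (0.25 log units; within the scatter) are within the scatter, as is a 1.0-fold higher number from compound 2 to compound 3 (0.00 log units; within the scatter), so no compound is called stronger than another. Compound 4, `COc1cc(Oc2cccc(Nc3ccccc3)c2)cc(OC)c1CCO`, differs from compound 1 by hydroxymethyl in place of (4-methoxybenzyl)amino on a saturated chain carbon bound to an aromatic carbon. Within the data shown here, none of the measured steps bears on this change: each of them only exchanges a single substituent on an aromatic carbon of the (4-methoxybenzyl)amino group, which here leaves entirely. Among the measured compounds shown here, with no comparable step, the expectation rests on the size of the change alone. Compound 4 is therefore expected to give a higher number, a step of a 4.2-fold higher number from compound 1 to compound 4 (0.63 log units; beyond the scatter). Compound 4 is estimated at 8000 nM, within 2000 nM to 40000 nM.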

Compound 4, half-maximal inhibitory concentration: 13900 nM
Compound 4: middle estimate off by 1.7-fold (0.24 log units), on the low side; the range from low to high includes it.
By their numbers in this assay, from the lowest: compounds 1, 2 and 3 (each within the scatter of the next); then compound 4.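

In this assay, within the data shown here, hydroxymethyl in place of the benzylamine arm gives a 7.4-fold higher number from compound 1 to compound 4 (0.87 log units; beyond the scatter) and a 4.2-fold higher number from compound 2 to compound 4 (0.62 log units; beyond the scatter) and a 4.1-fold higher number from compound 3 to compound 4 (0.62 log units; beyond the scatter) as the first steps beyond the scatter. What the saturated chain carbon bound to an aromatic carbon carries therefore matters, whereas the exchanges on the aromatic ring of the arm stayed within the scatter. No supporting measurement accounts for these steps.

The compounds shown do not separate the part played by the nitrogen from that of the aromatic ring. On these data alone, a plain amine or a carboxylic acid at this place remains open, as does a longer chain ending in the same ring.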